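The compounds below may be only part of what the source reports. "The series", "measured", "known", "first", "only" and "open" are said of these compounds alone.

Measured in a functional assay on T-24 cells (Homo sapiens) for cytotoxicity, read by colorimetric assay and MTT assay; on this read-out higher numbers stand for weaker inhibition and lower numbers for stronger inhibition:
- Compound 1 `COc1ccc2cc(-c3ccccc3)c(O)nc2c1` gives 10000 nM
- Compound 2 `COc1cc(OC)c2cc(-c3ccccc3)c(O)nc2c1` gives 10000 nM
- Compound 3 `COc1ccc(-c2cc3c(OC)cc(OC)cc3n(CCC#N)c2=O)cc1` gives 10000 nM

Compound 2, at 10000 nM, stands level with the other two compounds, so this small set shows no spread in this assay. The next compound, compound 4 `COc1cc(OC)c2cc(-c3ccc(O)cc3)c(O)nc2c1`, keeps the core of compound 2 and changes one thing, turning phenyl to 4-hydroxyphenyl: hydroxy in place of hydrogen on an aromatic carbon. In words, hydroxy takes the place of hydrogen on an aromatic carbon.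

Among the compounds with values here, only one measured step bears on this: no change at the digits printed from compound 1 to compound 2 (within the scatter). There, a methoxy in place of hydrogen on an aromatic carbon left the read-out flat. That is a different group at a different place, so it is only a loose guide. Compound 3 differs from compound 2 in more than one place, yet compound 3, at 10000 nM, also sits level. Within the data shown here, no measured compound shows what a hydroxy does here, so no step beyond the scatter is expected, though a gain in inhibition cannot be ruled out. The expected step is no change at the digits printed from compound 2 to compound 4 (within the scatter). For compound 4 the estimated value is 10000 nM, with an expected range from 3000 nM to 20000 nM.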

Compound 4, half-maximal inhibitory concentration: 10000 nM
Estimate against measurement, compound 4: no gap at the digits printed; the measured number falls inside the stated range.
By their numbers in this assay, from the lowest: compounds 1, 2, 3 and 4 (each within the scatter of the next).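

In this assay, hydroxy in place of hydrogen on the phenyl ring, para to a large group, gives no change at the digits printed from compound 2 to compound 4 (within the scatter). Within the data shown here, the earlier step concerned a methoxy at another place, so this is the first reading of a change on the phenyl ring itself, and adding this small group there leaves the value flat. Nothing shown here accounts for this flat result.

Going by these compounds, whether a larger or differently built group at this place, such as an amine, a carboxylic acid or a longer chain like butoxy, would shift the value remains open. All four compounds print the same number, so the set also leaves open which structural changes, on the phenyl ring or on the shared core, could give stronger inhibition in this assay at all.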